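Adding a hydroxy to compound 3

A few compounds are considered here, and "the series" means these few. Any claim that something is new, unique, unknown or untested is made for them only; others in the source may bear on it.

Measured in a functional assay on HT-29 cells (Homo sapiens) for antiproliferative activity, read by MTT assay, with a stated time of 48 h; a lower number here means a stronger inhibitor, a higher number a weaker inhibitor:
compound 1 `Oc1ccc2c(c1)CCc1ccc(O)c(c1)Oc1ccc(cc1O)CCc1cccc(O)c1O2`: 15900 nM
compound 2 `COc1cccc2c1Oc1cc(O)c(O)cc1CCc1ccc(O)c(c1)Oc1ccc(cc1)CC2`: 1980 nM
compound 3 `Oc1ccc2cc1Oc1ccc(cc1)CCc1cccc(O)c1Oc1ccc(cc1)CC2`: 7570 nM

Of these three numbers, compound 3 holds the middle place, with compound 1 higher and compound 2 lower, both gaps lying beyond the scatter. Compound 4 `Oc1ccc2cc1Oc1ccc(cc1)CCc1cccc(O)c1Oc1ccc(cc1O)CC2` follows from compound 3 by one change hydroxy in place of hydrogen on an aromatic carbon. For the measured compounds named here, no measured pair differs in one place only, so the size of this step can only be judged loosely. With nothing to set a direction, no step beyond the scatter is expected, and the estimated change is a 1.2-fold lower number from compound 3 to compound 4 (0.07 log units; within the scatter). The range stays wide, reaching towards compound 2 at 1980 nM and compound 1 at 15900 nM. For compound 4 the expected value is 6500 nM, with an estimated range of 2500 nM to 16000 nM.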

Compound 4, half-maximal inhibitory concentration: 17000 nM
Beside the measured number, compound 4's estimate is 2.6-fold (0.42 log units) below it; measured number outside the range, above it.
By their numbers in this assay, from the lowest: compound 2; then compound 3; then compounds 1 and 4 (each within the scatter of the next).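

In this assay, hydroxy in place of hydrogen on this aromatic carbon, ortho to a fused ring and meta to a fused ring, gives a 2.2-fold higher number from compound 3 to compound 4 (0.35 log units; beyond the scatter). For the compounds shown here, this is the only single-place step in the set, so it gives the first direct sign that this position responds to substitution: the change is modest but beyond the scatter, and it goes towards weaker inhibition. No measurement shown here accounts for this step.

From the compounds shown here alone, whether an amine or a carboxylic acid on the same carbon would shift the number in the same direction remains open. So does whether a hydroxy added elsewhere on the core would behave in the same way.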